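A few compounds are considered here, and "the series" means these few. Any claim that something is new, unique, unknown or untested is made for them only; others in the source may bear on it.

Measured so far:
compound 1 `CC(C)/N=C(\NC1=NC(=O)CN1c1ccc(Cl)c(Cl)c1)Nc1ccc(Cl)c(Cl)c1`: 0.454 h
compound 2 `CC(C)N1CC(=O)N=C1N/C(=N\C(=O)C(C)(C)C)Nc1ccc(Cl)c(Cl)c1`: > 1 h

Both compounds were tested in an in vivo ADME assay on the whole organism for metabolic stability, with Mus musculus as the target, read by LC-MS, at a dose of 160 mg/kg by the oral route; on this read-out lower numbers stand for a shorter-lived compound and higher numbers for a longer-lived compound. Compound 1 gives 0.454 h in this assay. Compound 2 gives > 1 h in this assay, and that value is a limit of the assay rather than a number. Within the two values shown, compound 2 sits at the limit of > 1 h in this assay, at which 1 of the 2 values shown sits.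

The next compound to be measured is compound 3 `CC(C)N1CC(=O)N=C1N/C(=N\C(=O)OC(C)(C)C)Nc1ccc(Cl)c(Cl)c1`. It differs from compound 2 in one place: tert-butoxy in place of tert-butyl on a carbonyl carbon. Among the measured compounds shown here, since no step between two measured compounds is known here, there is no measured guide to how this kind of change moves the half-life. The expected step from compound 2 to compound 3 is no change beyond the usual scatter, and the estimate of that step is a step that the limit leaves unreadable from compound 2 to compound 3. On that basis compound 3 is expected to give about 1.3 h in this assay, with a likely range from 0.6 h to 3 h, and a real chance that the assay again reports only a limit.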

Compound 3, half-life: 0.263 h
Compound 3: the middle estimate sits 4.9-fold (0.69 log units) above what was measured; measured number below the stated range.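

In this assay, tert-butoxy in place of tert-butyl on a carbonyl carbon gives an at least 3.8-fold lower number from compound 2 to compound 3 (0.58 log units; beyond the scatter). Among the compounds shown here, this is the first measured sign that the half-life responds to a change at this place, where the carbonyl carbon's other neighbour is an amide-type nitrogen: the two compounds differ only in the oxygen that links the tert-butyl part to the carbonyl, and the rest of the structure is the same. The true size of the step stays unknown because the value of compound 2 is a limit of the assay and not a number: the limit of > 1 h in this assay, at which 1 of the 3 values shown sits.

The compounds shown do not tell why the half-life is shorter with tert-butoxy, and a single pair cannot say whether the same change would act in the same way on a different core. On these data alone, how a methoxy group, an amine or a longer chain on the same carbonyl carbon would compare also remains open.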